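The compounds below may be only part of what the source reports. "The series", "measured", "known", "first", "only" and "open" are said of these compounds alone.

Compound 1 `CCCCCN1CCC(CCC(=O)c2cc(Cl)c(N)cc2OCc2cc(OC)cc(OC)c2)CC1` is measured in an assay on isolated protein for binding affinity to 5-hydroxytryptamine receptor 4 (Cavia porcellus), read by radioligand binding (a higher number here means a weaker inhibitor, a lower number a stronger inhibitor), at 0.813 nM, the second highest of three numbers. Compound 3 `COc1cc(COc2cc(N)c(Cl)cc2C(=O)CCC2CCN(CCN(C)S(C)(=O)=O)CC2)cc(OC)c1` differs from compound 1 by methyl(methylsulfonyl)amino in place of propyl on a saturated chain carbon, two bonds along the chain from an amine nitrogen in a ring. In this assay compound 3 gives 0.468 nM; that step, a 1.7-fold lower number from compound 1 to compound 3 (0.24 log units; within the scatter), stays within the scatter. Compound 2 `CS(=O)(=O)NCCN1CCC(CCC(=O)c2cc(Cl)c(N)cc2OCc2ccccc2)CC1` gives 1.78 nM. Compound 4 `COc1cc(COc2cc(N)c(Cl)cc2C(=O)CCC2CCN(CCCNS(C)(=O)=O)CC2)cc(OC)c1` is not yet measured; it differs from compound 1 by methanesulfonamido in place of ethyl on a saturated chain carbon, three bonds along the chain from an amine nitrogen in a ring. Because the comparable exchange gave a 1.7-fold lower number from compound 1 to compound 3 (0.24 log units; within the scatter), no step beyond the scatter is expected, and the estimated step is a 1.4-fold lower number from compound 1 to compound 4 (0.13 log units; within the scatter). Compound 4 is therefore expected to give about 0.6 nM in this assay, between 0.2 nM and 1.8 nM.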

Compound 4, inhibition constant: 0.339 nM
Compound 4: the middle estimate sits 1.8-fold (0.25 log units) above what was measured; low and high end bracket the measured number.
By their numbers in this assay, from the lowest: compounds 4, 3 and 1 (each within the scatter of the next, the first and the last beyond it); then compound 2.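

In this assay, among these compounds, placing methanesulfonamido on the chain gives the first step at this position to clear the scatter, a 2.4-fold lower number from compound 1 to compound 4 (0.38 log units; beyond the scatter), so a chain ending in this group can do more than match the pentyl chain of compound 1. The two chains ending in sulfonyl groups cannot be told apart, with a 1.4-fold lower number from compound 3 to compound 4 (0.14 log units; within the scatter) as the step between them. Nothing on hand explains the gain.

Still open, on these data alone, is whether a sulfonyl group is needed at all, or whether an amine or a carboxylic acid at the chain end would do as well. A longer chain carrying methanesulfonamido also remains untested among these compounds.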